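A few compounds are considered here, and "the series" means these few. Any claim that something is new, unique, unknown or untested is made for them only; others in the source may bear on it.

For the measured compounds named here, compound 2 `COc1cc(N)c(Cl)cc1C(=O)NC1CCN(CCCCCCCCO)CC1` gives 79.4 nM in an assay on HEK293 cells for displacement of a labelled ligand from 5-hydroxytryptamine receptor 4 (Homo sapiens), read by scintillation counting (on this read-out higher numbers stand for weaker inhibition and lower numbers for stronger inhibition), the lower of the two numbers so far; compound 1 `CCN1CCC(NC(=O)c2cc(Cl)c(N)cc2OC)CC1` gives 1000 nM. Compound 3 `COc1cc(N)c(Cl)cc1C(=O)NC1CCN(CCCCCCCCN2C(=O)c3ccccc3C2=O)CC1` differs from compound 2 by a group of 11 heavy atoms (8 carbon, 1 nitrogen, 2 oxygen; one five-membered non-aromatic ring with 1 hetero atom, one six-membered aromatic ring of carbon only) in place of one oxygen atom, on a saturated chain carbon, eight bonds along the chain from an amine nitrogen in a ring. Going by the values given here, the only measured step, a 13-fold lower number from compound 1 to compound 2 (1.10 log units; beyond the scatter), concerns growth at the same chain rather than its end group, so it bears on this change only loosely. With wide uncertainty, the expected step is a 1.6-fold lower number from compound 2 to compound 3 (0.20 log units; within the scatter). Compound 3 is therefore estimated at 50 nM, within 10 nM to 250 nM.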

Compound 3, inhibition constant: 39.8 nM
Compound 3: the middle estimate sits 1.3-fold (0.10 log units) above what was measured; the measured number falls inside the stated range.
By their numbers in this assay, from the lowest: compounds 3 and 2 (each within the scatter of the next); then compound 1.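

In this assay, the group of 11 heavy atoms in place of the hydroxy gives a 2.0-fold lower number from compound 2 to compound 3 (0.30 log units; within the scatter), a step within the scatter, so the two compounds cannot be told apart. This chain end, eight bonds along the chain from an amine nitrogen in a ring, therefore carries a five-membered non-aromatic ring and a six-membered aromatic ring with no change beyond the scatter. No measurement shown explains this result. Open, as far as these compounds go, is whether an amine or a carboxylic acid at the chain end would read the same, and whether a shorter or longer chain would tolerate the same end group.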